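The compounds below may be only part of what the source reports. "The series", "measured", "known", "first", "only" and "open" are said of these compounds alone.

Measured so far in a functional assay on A-375 cells (Homo sapiens) for activation, with a stated time of 3 days; on this read-out lower numbers stand for an effect already at smaller amounts and higher numbers for an effect only at larger amounts of compound:
- compound 1 `O=C(Nc1ccc(-c2cscn2)cc1)C1CCCN(Cc2cccc(F)c2)C1`: 5000 nM
- compound 2 `O=C(Nc1ccc(-c2cscn2)cc1)C1CCCN(Cc2ccc(F)cc2)C1`: 5000 nM
- compound 3 `O=C(Nc1ccc(-c2cscn2)cc1)C1CCCN(Cc2cccc(C(F)(F)F)c2)C1`: > 20000 nM

Compound 3 stands at > 20000 nM, which is a limit of this assay and not a number. Going by the values given here, it is the only one of the three compounds reported this way, as the limit of > 20000 nM in this assay, at which 1 of the 3 values shown sits, records.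

The next compound, compound 4 `O=C(Nc1ccc(-c2cscn2)cc1)C1CCCN(Cc2cccc(OC(F)(F)F)c2)C1`, keeps the shared core and changes one group: trifluoromethoxy in place of trifluoromethyl on an aromatic carbon. In words, trifluoromethoxy takes the place of trifluoromethyl on an aromatic carbon.

Among the compounds with values here, three measured steps bear on this change. The fluoro compounds show no change at the digits printed from compound 1 to compound 2 (within the scatter). Replacing fluoro with trifluoromethyl gives an at least 4.0-fold higher number from compound 1 to compound 3 (0.60 log units; beyond the scatter), and the other route to the same compound gives an at least 4.0-fold higher number from compound 2 to compound 3 (0.60 log units; beyond the scatter). Neither of these two larger steps has a fixed size, since each ends at a limit. Within the data shown here, no measured step involves trifluoromethoxy, so the expectation rests on its likeness to the trifluoromethyl group of compound 3, which gave > 20000 nM. No step beyond the scatter is therefore expected, although a return towards the fluoro compounds remains possible.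

This estimate amounts to an expected at least 1.3-fold lower number from compound 3 to compound 4 (0.12 log units; that floor lies within the scatter). For compound 4 the estimated value is 15000 nM, with an expected range from 6000 nM to 30000 nM.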

Compound 4, half-maximal effective concentration: > 20000 nM
Compound 4 was reported as a limit; the forecaster's own chance of this, stated with the estimate: 50%; at least 1.3-fold (0.12 log units) between middle value and limit.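

In this assay compound 4 gives > 20000 nM, which is a limit of the assay and not a number. Trifluoromethoxy in place of fluoro gives an at least 4.0-fold higher number from compound 1 to compound 4 (0.60 log units; beyond the scatter), so a second group at this place, meta to a large group, now separates from fluoro in the same direction as trifluoromethyl did, where before only one such group had been seen. The step from trifluoromethyl to trifluoromethoxy itself cannot be read, as compound 3 and compound 4 both end at a limit, and the record at that limit has grown: the limit of > 20000 nM in this assay, at which 2 of the 4 values shown sit.

Going by these compounds, what stays open is how far past the limit compound 3 and compound 4 lie, and therefore whether the two groups differ from each other at all in this assay. Also open, on these data alone, is which groups at this place on the aromatic ring would keep a value in the range of the fluoro compounds, and a chlorine atom, a methoxy group or an amine there would give the first readable steps against compound 1.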